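The compounds below may be only part of what the source reports. "The series", "measured", "known", "first", "only" and "open" are said of these compounds alone.

Compound 1, `CCc1cc(Nc2cc(Cl)cc(Cl)c2)nc(N)n1`, gives 36% in an assay on cells for inhibition of S-adenosylmethionine decarboxylase proenzyme (Homo sapiens), read by mass spectrometry, at pH 7.2, tested at 180 uM; on this read-out higher numbers stand for more inhibition at the one concentration tested (going by the name of the read-out) and lower numbers for less inhibition.
Compound 2, `Cc1nc(N)nc(Nc2cc(Cl)cc(Cl)c2)c1C`, gives 25% in this assay.
Compound 3, `Cc1cc(Nc2cc(Cl)cc(Br)c2)nc(N)n1`, gives 33% in this assay.

The three numbers lie close together: the gap from compound 3 to compound 1 and the gap from compound 3 to compound 2 both fall within the usual scatter of repeated measurements, so none of the three can be set apart from the others on these data. Compound 4, `Cc1cc(Nc2cc(Cl)cc(C(F)(F)F)c2)nc(N)n1`, has not yet been measured. It differs from compound 3 in one place: trifluoromethyl in place of bromo on an aromatic carbon. For the measured compounds named here, no pair of measured compounds differs in just one place, so there is no earlier step of this kind to judge the size against. With the measured numbers so close, no step beyond the scatter is expected, and the estimated change no change at the digits printed from compound 3 to compound 4 (within the scatter) reflects that. For compound 4 the expected value in this assay is 33%, with a range from 18% to 48%.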

Compound 4, a percentage reported as inhibition, at one concentration (the size of the read-out at that concentration, not a potency): 39%
Compound 4: middle estimate off by 6 percentage points, on the low side, and the stated range covers the measured number.
By their numbers in this assay, from the lowest: compounds 2, 3, 1 and 4 (each within the scatter of the next, the first and the last beyond it).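

Trifluoromethyl in place of bromo on this aromatic carbon gives a number 6 percentage points higher from compound 3 to compound 4 (within the scatter) in this assay. For the compounds shown here, this is the first pair here that differs in just one place, and it shows that going from one heavy atom to four at this position leaves the reading within the scatter. No measurement shown here accounts for this result.

From the compounds shown here alone, whether a group of another kind, such as an amine, a carboxylic acid or a longer chain, would give a step beyond the scatter at this position remains open.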